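Ring-size and chloro changes on an anilinoquinazoline series

The source may hold more compounds than are shown below. What is called first, only, known or untested is meant among the compounds shown, and "the series" means these compounds.

Compound 1 `COc1cc2ncnc(Nc3ccc(Cl)c(C(F)(F)F)c3)c2cc1OCCCN1CCNCCNCCNCC1` is the reference of the set. In a functional assay on A549 cells (Homo sapiens) for antiproliferative activity, read by MTT assay, with a stated time of 72 h (on this read-out lower numbers stand for stronger inhibition and higher numbers for weaker inhibition), compound 1 gives 5350 nM. Compound 2 `COc1cc2ncnc(Nc3cccc(C(F)(F)F)c3)c2cc1OCCCN1CCNCCNCCNCC1` differs from compound 1 by one change, (hydrogen in place of chloro on an aromatic carbon), and in this assay compound 2 gives 15700 nM; the step is a 2.9-fold higher number from compound 1 to compound 2 (0.47 log units; beyond the scatter). Compound 3 `COc1cc2ncnc(Nc3ccc(Cl)c(C(F)(F)F)c3)c2cc1OCCCN1CCNCCNCC1` carries a different core, and how the two cores differ is counted here: a group of 9 heavy atoms (6 carbon, 3 nitrogen; one nine-membered non-aromatic ring with 3 hetero atoms) in place of a group of 12 heavy atoms (8 carbon, 4 nitrogen; one twelve-membered non-aromatic ring with 4 hetero atoms), on a saturated chain carbon, three bonds along the chain from an oxygen on an aromatic ring. In this assay compound 3 gives 6230 nM, so the core change gives a 1.2-fold higher number from compound 1 to compound 3 (0.07 log units; within the scatter), which is within the scatter.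

Compound 4 `COc1cc2ncnc(Nc3cccc(C(F)(F)F)c3)c2cc1OCCCN1CCNCCNCC1` is not yet measured. It stands to compound 3 as compound 2 stands to compound 1: hydrogen in place of chloro on an aromatic carbon. The surroundings of the place are the same in both pairs, so this is the same change, made twice in the set. Going by the values given here, the step from compound 1 to compound 2 is the only measured instance of it, and since the core change from compound 1 to compound 3 is within the scatter, a step of similar size is expected in this assay, namely a 2.9-fold higher number from compound 3 to compound 4 (0.46 log units; beyond the scatter). Compound 4 is therefore estimated at 18000 nM, with a likely range of 9000 nM to 36000 nM.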

Compound 4, half-maximal inhibitory concentration: 37300 nM
Compound 4: middle estimate off by 2.1-fold (0.32 log units), on the low side; the whole stated range lies below it.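

Hydrogen in place of chloro on the core of compound 3 gives a 6.0-fold higher number from compound 3 to compound 4 (0.78 log units; beyond the scatter) in this assay, and this step does not differ from the one on the core of compound 1: the same change on two cores in this assay, a 2.9-fold higher number (0.47 log units; beyond the scatter) from compound 1 to compound 2 and a 6.0-fold higher number (0.78 log units; beyond the scatter) from compound 3 to compound 4, 2.0-fold (0.31 log units) apart, within the scatter of two such steps

The ring change, read without the chloro, gives a 2.4-fold higher number from compound 2 to compound 4 (0.38 log units; beyond the scatter), and this step likewise does not differ from its counterpart with the chloro present: the same change on two cores in this assay, a 1.2-fold higher number (0.07 log units; within the scatter) from compound 1 to compound 3 and a 2.4-fold higher number (0.38 log units; beyond the scatter) from compound 2 to compound 4, 2.0-fold (0.31 log units) apart, within the scatter of two such steps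

So in this small set the loss of the chloro carries from one core to the other in the same direction and without a resolved difference in size, but two instances of each change cannot show that the step is constant, nor that the two changes act independently, and they give no cause for either step.

Going by these compounds, it remains open whether a fluoro, bromo or methyl group in place of the chloro would follow the same course on both cores. On these data alone, it is equally open whether the step would carry to a core with an open-chain amine in place of the ring.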